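From Fluoro to Hydroxy on Compound 2

The compounds below may be only part of what the source reports. "The series", "measured", "known", "first", "only" and "open" are said of these compounds alone.

Compound 1 (`COc1ccc(N(C)c2ccnc(Cl)n2)cc1F`): 651 nM
Compound 2 (`COc1ccc(N(C)c2cc(C)nc(C)n2)cc1F`): 632 nM

Going by the values given here, in a functional assay on A549 cells (Homo sapiens) for antiproliferative activity, read by MTT assay, with a stated time of 48 h (a lower number here means a stronger inhibitor, a higher number a weaker inhibitor), compound 1 (651 nM) and compound 2 (632 nM) lie within the scatter of each other, so compound 2 stands level with the only other measured compound. Compound 3 (`COc1ccc(N(C)c2cc(C)nc(C)n2)cc1O`) has hydroxy in place of fluoro on an aromatic carbon, ortho to a methoxy group (hydroxy in place of fluoro on an aromatic carbon). Among the compounds with values here, no measured pair of compounds shows a change at this place, so the data give no direct guide to its effect. A modest shift toward stronger inhibition in this assay is nevertheless expected, and the estimate for it is a 1.6-fold lower number from compound 2 to compound 3 (0.20 log units; within the scatter) with considerable uncertainty. For compound 3 the estimated value is 400 nM with a range from 120 nM to 1400 nM as the expected span.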

Compound 3, half-maximal inhibitory concentration: 113 nM
Estimate against measurement, compound 3: 3.5-fold (0.55 log units) above, outside the stated range (below it).
By their numbers in this assay, from the lowest: compound 3; then compounds 2 and 1 (each within the scatter of the next).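

Exchanging fluoro for hydroxy on an aromatic carbon, ortho to a methoxy group, gives a 5.6-fold lower number from compound 2 to compound 3 (0.75 log units; beyond the scatter) in this assay, which marks this position as one where the substituent matters. The earlier compounds shown here both carried fluoro here and so could not show this. The exchange adds one hydrogen-bond donor and one hydrogen-bond acceptor, but nothing measured here links either of them to the step, and no data on the origin of the change are available.

Only fluoro and hydroxy are shown at this place, so it remains open how an amine or a carboxylic acid would read there in this assay. On these data alone, it is also open whether the same exchange would give a step of similar size on compound 1, whose core differs from that of compound 2.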